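Working notes: from compound 3 to compound 4

This account rests on a few compounds, and the source may have more. Where it says the series, first, only, none or still open, it means among the compounds named here.

Measured in a functional assay on A549 cells (Homo sapiens) for antiproliferative activity, read by MTT assay, with a stated time of 24 h; a higher number here means a weaker inhibitor, a lower number a stronger inhibitor:
- compound 1 `O=C(NNc1ccccc1F)c1ccc(NS(=O)(=O)c2cnc(O)nc2O)cc1` gives 11700 nM
- compound 2 `O=C(NNc1ccccc1F)c1cccc(NS(=O)(=O)c2cnc(O)nc2O)c1` gives 11100 nM
- compound 3 `Cc1ccccc1NNC(=O)c1ccccc1NS(=O)(=O)c1cnc(O)nc1O` gives > 20000 nM, a limit and not a number

Compound 3 stands at the limit of > 20000 nM in this assay, at which 1 of the 3 values shown sits, so it offers no number to step from.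

Compound 4 `O=C(NNc1cccc(Cl)c1)c1ccccc1NS(=O)(=O)c1cnc(O)nc1O` keeps the core of compound 3 and carries 3-chlorophenyl in place of 2-methylphenyl on an amine nitrogen. For the measured compounds named here, no measured pair shows this change alone. Going by the values given here, compound 1 at 11700 nM and compound 2 at 11100 nM lie within the scatter of each other and give the only numbers to lean on. A modest step toward stronger inhibition in this assay is expected, an at least 1.4-fold lower number from compound 3 to compound 4 (0.15 log units; that floor lies within the scatter), though a reading at the limit remains possible. For compound 4 the estimated value is 14000 nM, expected to fall within 8000 nM to 20000 nM in most repeats.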

Compound 4, half-maximal inhibitory concentration: 5290 nM
Compound 4: middle estimate off by 2.6-fold (0.42 log units), on the high side; measured number outside the range, below it.
By their numbers in this assay, from the lowest: compound 4; then compounds 2 and 1 (each within the scatter of the next). At a limit, above all of these: compound 3.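

In this assay, 3-chlorophenyl in place of 2-methylphenyl on an amine nitrogen gives an at least 3.7-fold lower number from compound 3 to compound 4 (0.57 log units; beyond the scatter), so this position can carry a change that moves the core of compound 3 to a measurable number. The size of the step is only a floor, as one end is a limit and not a number: the limit of > 20000 nM in this assay, at which 1 of the 4 values shown sits.

The step exchanges the whole aryl group, so the chlorine and its place on the ring remain unseparated. From the compounds shown here alone, whether 3-methylphenyl or 2-chlorophenyl on this nitrogen would read closer to compound 4 stays open.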